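Shifting a nitrophenyl onto the chain of compound 3

The source may report more compounds than this note shows. Statements on the series, on what has been measured and on what is new or still open speak of the compounds shown alone.

Measured compounds in an ADME assay on HepG2 2.2.15 cells (Homo sapiens) for cytotoxicity, read by MTT assay, with a stated time of 72 h; a lower number here means that less compound is tolerated, a higher number that more compound is tolerated:
Compound 1, `Cc1cc(C)cc(Cc2nc(SCCOc3ccc([N+](=O)[O-])cc3)[nH]c(=O)c2I)c1`: compound 1 gives 96600 nM.
Compound 2, `Cc1cc(C)cc(Cc2nc(SCc3ccc(C#N)cc3)[nH]c(=O)c2I)c1`: compound 2 gives 43200 nM.
Compound 3, `Cc1cc(C)cc(Cc2nc(SCCOc3ccccc3)[nH]c(=O)c2I)c1`: compound 3 gives > 100000 nM, which is a limit of the assay and not a number.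

Compound 3 therefore stands at the top of the measured set, known only as a limit; the limit of > 100000 nM in this assay, at which 1 of the 3 values shown sits, marks where it sits. Compound 4, `Cc1cc(C)cc(Cc2nc(SCCc3ccc([N+](=O)[O-])cc3)[nH]c(=O)c2I)c1`, differs from compound 3 in one place: 4-nitrophenyl in place of phenoxy on a saturated chain carbon, two bonds along the chain from a sulfur.

Going by the values given here, two measured steps bear on this change. The first is an at least 1.0-fold higher number from compound 1 to compound 3 (0.01 log units; that floor lies within the scatter), which lies within the scatter and shows that the same group sitting on the phenoxy ring of compound 1 leaves the value essentially where compound 3 stands. The second is an at least 2.3-fold higher number from compound 2 to compound 3 (0.36 log units; beyond the scatter), a step beyond the scatter in which a different aryl group attached directly to the chain gave a lower number than compound 3. Compound 4 resembles compound 1 in carrying the nitro-bearing ring and resembles compound 2 in having the ring bound through carbon rather than oxygen, so a small downward step is expected, an at least 1.2-fold lower number from compound 3 to compound 4 (0.09 log units; that floor lies within the scatter), within or near the scatter. For compound 4 in this assay the expected value is 80000 nM, in the range 35000 nM to 180000 nM.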

Compound 4, half-maximal cytotoxic concentration: 66600 nM
Beside the measured number, compound 4's estimate is 1.2-fold (0.08 log units) above it; measured number inside the range.
By their numbers in this assay, from the lowest: compounds 2, 4 and 1 (each within the scatter of the next, the first and the last beyond it). At a limit, above all of these: compound 3.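

In this assay, putting 4-nitrophenyl in place of 4-nitrophenoxy on a saturated chain carbon, two bonds along the chain from a sulfur, gives a 1.5-fold lower number from compound 1 to compound 4 (0.16 log units; within the scatter). Going by these compounds alone, this is the first step in the set read between two actual numbers at this place, and it shows that the nitro-bearing ring can sit on the chain with or without the oxygen and give no change that stands clear of the scatter. Set against the plain phenoxy group, the same place gives an at least 1.5-fold lower number from compound 3 to compound 4 (0.17 log units; that floor lies within the scatter), which is only a floor and does not separate the two groups, as compound 3 is known only as a limit: the limit of > 100000 nM in this assay, at which 1 of the 4 values shown sits.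

From the compounds shown here alone, how far compound 4 truly lies from compound 3 therefore stays open, and with it whether the exchange of phenoxy for 4-nitrophenyl does anything at all in this assay. Also open, going by these compounds, is whether an amine or a carboxylic acid in place of the nitro on this ring, or a longer chain between the sulfur and the ring, would move the number beyond the scatter.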